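This account rests on a few compounds, and the source may have more. Where it says the series, first, only, none or still open, it means among the compounds named here.

Values in a functional assay on HeLa cells (Homo sapiens) for inhibition, read by MTT assay, with a stated time of 48 h; on this read-out lower numbers stand for stronger inhibition and higher numbers for weaker inhibition:
- compound 1 `CCOC(=O)C1=C(NN=C(C(C)=O)C(C)=O)Nc2[nH]nc(C)c2C1c1ccc(N(C)C)cc1`: 17000 nM
- compound 2 `CCOC(=O)C1=C(N)Nc2[nH]nc(C)c2C1c1ccc(N(C)C)cc1`: 6220 nM
- compound 3 `CCOC(=O)C1=C(N/N=C(/Cl)C#N)Nc2[nH]nc(C)c2C1c1ccc(N(C)C)cc1`: not yet measured

Of the two measured compounds, compound 2 has the lower number at 6220 nM, which makes it the stronger inhibitor in this assay.

The next change starts from compound 2 and gives compound 3: a group of 5 heavy atoms (2 carbon, 2 nitrogen, 1 chlorine; no ring) in place of a hydrogen atom, on an amine nitrogen. The new group sits on an amine nitrogen whose other neighbours are: double-bonded ring carbon.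

Among the compounds with values here, only one measured step bears on this change: a 2.7-fold lower number from compound 1 to compound 2 (0.44 log units; beyond the scatter). That step is modest and removes a different group from an amine nitrogen, whereas the step to compound 3 adds one there. Read in reverse, it suggests that a modest rise in the number is likely in this assay. Within the data shown here, a single step cannot show how this smaller group will behave, and the data offer no other substituted compound for comparison, so the range is kept wide and includes no change.

The expected step is a 1.8-fold higher number from compound 2 to compound 3 (0.25 log units; within the scatter). For compound 3 the estimated value is 11000 nM, with an expected range of 4000 nM to 30000 nM.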

Compound 3, half-maximal inhibitory concentration: 26200 nM
Compound 3: middle estimate off by 2.4-fold (0.38 log units), on the low side; the measured number falls inside the stated range.
By their numbers in this assay, from the lowest: compound 2; then compounds 1 and 3 (each within the scatter of the next).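

In this assay the new group on the amine nitrogen gives a 4.2-fold higher number from compound 2 to compound 3 (0.62 log units; beyond the scatter) in a modest step beyond the scatter, so two different substituents at this place now both read above the unsubstituted amine. The two substituents differ in heavy atoms and in make-up, yet exchanging one for the other gives a 1.5-fold higher number from compound 1 to compound 3 (0.19 log units; within the scatter) and stays within the scatter, so the series shows no separation between them at this place. The free amine therefore stands apart from both substituted compounds, though no measurement at hand accounts for these steps.

Open, going by these compounds, is whether a single methyl or acetyl group on this amine nitrogen would read closer to the free amine than to the two larger groups, and whether a group ending in a carboxylic acid or a primary amine would follow the same trend. Also open, on these data alone, is whether any of this holds when the ethyl ester or the dimethylamino group on the shared core is replaced, for instance by a carboxylic acid or a simple methoxy group.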